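Ether swap on the thiophene sulfonamide series

This account rests on a few compounds, and the source may have more. Where it says the series, first, only, none or still open, it means among the compounds named here.

Measured compounds:
compound 1 `O=S(=O)(NCCNC(=S)Nc1cc(C(F)(F)F)cc(C(F)(F)F)c1)c1ccc(-c2ccccc2OCc2cccc(O)c2)s1`: in a functional assay on HL-60 cells (Homo sapiens) for inhibition, read by CCK-8 assay, with a stated time of 48 h (on this read-out higher numbers stand for weaker inhibition and lower numbers for stronger inhibition), compound 1 gives > 50000 nM, a limit of the assay.
compound 2 `O=[N+]([O-])c1ccc(Oc2ccccc2-c2ccc(S(=O)(=O)NCCNC(=S)Nc3cc(C(F)(F)F)cc(C(F)(F)F)c3)s2)cc1`: in this assay compound 2 gives 7200 nM.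
compound 3 `COc1ccc(NC(=O)NCCNS(=O)(=O)c2ccc(-c3ccccc3Oc3ccc([N+](=O)[O-])cc3)s2)cc1`: in this assay compound 3 gives > 50000 nM, a limit of the assay.

The change from compound 2 to compound 1 is 3-hydroxybenzyl in place of 4-nitrophenyl on an oxygen on an aromatic ring and it produces an at least 6.9-fold higher number from compound 2 to compound 1 (0.84 log units; beyond the scatter), ending at the limit of > 50000 nM in this assay, at which 2 of the 3 values shown sit. How the cores of compound 2 and compound 3 differ is not broken down here. Compound 4 `COc1ccc(NC(=O)NCCNS(=O)(=O)c2ccc(-c3ccccc3OCc3cccc(O)c3)s2)cc1` carries the same change at the same place relative to compound 3: 3-hydroxybenzyl in place of 4-nitrophenyl on an oxygen on an aromatic ring. Compound 3 already sits at the limit of the assay. Weak inhibition is therefore expected for compound 4, with the step that the limit leaves unreadable from compound 3 to compound 4 resting on compound 2 and compound 1 through an at least 6.9-fold higher number from compound 2 to compound 1 (0.84 log units; beyond the scatter). Compound 4 is estimated at 70000 nM, between 25000 nM and 250000 nM, and is expected to be reported only as a limit.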

Compound 4, half-maximal inhibitory concentration: > 20000 nM
Compound 4 ended at the assay's limit (the forecaster's own chance of this, stated with the estimate: 85%); the middle value is on the limit's open side.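

The step between compound 3 and compound 4 cannot be read, as both results are limits of the assay. On these data alone, it remains open whether 3-hydroxybenzyl in place of 4-nitrophenyl weakens inhibition on the core of compound 3 as on that of compound 2.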